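From Hydroxy to Isopropyl: One Small Structural Step

The source may hold more compounds than are shown below. What is called first, only, known or untested is meant among the compounds shown, and "the series" means these compounds.

Measured so far:
- compound 1, `Clc1ccc(-c2[nH]c3ccc(Cl)cc3c2SC2CCNCC2)cc1`: 26%
- compound 2, `CN1CCC(Sc2c[nH]c3ccc(O)cc23)CC1`: 9%

Of the compounds shown here, two have been tested in a functional assay on the whole organism for inhibition, with Mus musculus as the target, at a dose of 30 mg/kg; on this read-out lower numbers stand for less inhibition and higher numbers for more inhibition at the one dose given (going by the name of the read-out). Compound 1 gives 26%, while compound 2 gives 9%, the lower of the two numbers, and the gap between them lies beyond the usual scatter of this kind of measurement. Compound 2 is therefore the starting point for the step followed here.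

Compound 3, `CC(C)c1ccc2[nH]cc(SC3CCN(C)CC3)c2c1`, is not yet measured. It differs from compound 2 in a single place: isopropyl in place of hydroxy on an aromatic carbon. The hydroxy group leaves, and the isopropyl group enters on the same aromatic carbon.

For the measured compounds named here, no pair of measured compounds shows the effect of this particular change, so the expectation rests only on the two values at hand. Compound 1, with its larger and more substituted structure, gives 26%, which suggests that a less polar substituent is not harmful on this read-out. For compound 3 a small upward step of about a number 6 percentage points higher from compound 2 to compound 3 (within the scatter) is expected, though it may not clear the scatter. The estimate for compound 3 in this assay is 15%, within a range from 0% to 35%.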

Compound 3, a percentage reported as inhibition, in the whole organism at one dose (the size of the read-out at that dose, not a potency): 48%
Compound 3: middle estimate off by 33 percentage points, on the low side; measured number outside the range, above it.
By their numbers in this assay, from the lowest: compound 2; then compound 1; then compound 3.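

In this assay, isopropyl in place of hydroxy on this aromatic carbon gives a number 39 percentage points higher from compound 2 to compound 3 (beyond the scatter). Compounds 1 and 2 differ in more than one place, so they could not isolate any single change, whereas this pair shows that what sits on this one carbon of the shared core can by itself shift the result well beyond the scatter, with the rest of the structure unchanged. The change replaces a group that carries a hydrogen-bond donor and a hydrogen-bond acceptor with an all-carbon group that carries neither, but no measurement at hand accounts for the step.

This single pair leaves open whether the larger number goes with the arrival of isopropyl or simply with the departure of hydroxy, and a hydrogen atom, methyl or methoxy on the same carbon would help to separate the two. It also leaves open how far the trend extends, since a tert-butyl group, a chlorine atom or an amine at this position could each give a quite different number in this assay.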